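The source may hold more compounds than are shown below. What is called first, only, known or untested is meant among the compounds shown, and "the series" means these compounds.

Three ureas sharing one core have been measured in an assay on isolated protein for activation of Nicotinamide phosphoribosyltransferase (Homo sapiens); a lower number here means that less compound is needed, a higher number that more compound is needed for the effect. Compound 1 `CN(Cc1ccccc1)S(=O)(=O)c1ccc(NC(=O)NCc2ccncc2)cc1` gives 23 nM, compound 2 `O=C(NCc1ccncc1)Nc1ccc(S(=O)(=O)NCc2ccccc2)cc1` gives 102 nM, and compound 3 `O=C(NCc1ccncc1)Nc1ccc(S(=O)(=O)N2CC3CCC(C2)O3)cc1` gives 279 nM. Compound 3 thus stands with the highest number of the three, its nearest neighbour being compound 2 and its furthest compound 1, both beyond the scatter.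

Compound 4 `O=C(NCc1ccncc1)Nc1ccc(S(=O)(=O)N2CCc3ccccc3C2)cc1` is reached from compound 3 by a single change: a group of 10 heavy atoms (9 carbon, 1 nitrogen; one six-membered non-aromatic ring with 1 hetero atom, one six-membered aromatic ring of carbon only) in place of a group of 8 heavy atoms (6 carbon, 1 nitrogen, 1 oxygen; one five-membered non-aromatic ring with 1 hetero atom, one six-membered non-aromatic ring with 2 hetero atoms), on a sulfonyl sulfur.

For the measured compounds named here, two measured steps bear on this. The step of a 12-fold higher number from compound 1 to compound 3 (1.08 log units; beyond the scatter) showed that exchanging an aromatic-ring-bearing tertiary sulfonamide substituent for the oxygen-containing bicycle raised the number by a large amount, and the step of a 2.7-fold higher number from compound 2 to compound 3 (0.44 log units; beyond the scatter) showed a modest rise in the same direction from the secondary benzyl analogue. Compound 4 reverses that direction, restoring an aromatic ring on a tertiary sulfonamide nitrogen, so a drop beyond the scatter is expected, plausibly toward the region of compound 1, whose value 23 nM sets the lowest number seen so far.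

Compound 4 is therefore estimated at 40 nM, within a range of 15 nM to 120 nM. This estimate corresponds to an expected step of a 7.0-fold lower number from compound 3 to compound 4 (0.84 log units; beyond the scatter).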

Compound 4, half-maximal effective concentration: 142 nM
Estimate against measurement, compound 4: 3.6-fold (0.55 log units) below; measured number above the stated range.
By their numbers in this assay, from the lowest: compound 1; then compounds 2, 4 and 3 (each within the scatter of the next, the first and the last beyond it).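

In this assay, 1,2,3,4-tetrahydroisoquinolin-2-yl on the sulfonyl sulfur gives a 2.0-fold lower number from compound 3 to compound 4 (0.29 log units; within the scatter) and a 1.4-fold higher number from compound 2 to compound 4 (0.14 log units; within the scatter) so the numbers do not separate this group from the group of compound 3 or from the benzylamino group of compound 2. Against benzyl(methyl)amino the same group gives a 6.2-fold higher number from compound 1 to compound 4 (0.79 log units; beyond the scatter) which shows that an aromatic ring and a fully substituted sulfonamide nitrogen do not by themselves bring a compound to the level of compound 1, and among these four compounds only compound 1 stands apart from the rest. No information is available here that would explain why the ring-closed group and benzyl(methyl)amino differ.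

The compounds shown leave open which feature of benzyl(methyl)amino carries its advantage, and whether it would survive with ethyl in place of the methyl or with a longer chain, such as phenethyl, in place of the benzyl. They also leave open whether a carboxylic acid or an amine on the phenyl ring of benzyl(methyl)amino would be tolerated in this position.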